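This account rests on a few compounds, and the source may have more. Where it says the series, first, only, none or still open, it means among the compounds named here.

Measured compounds:
Compound 1, `Brc1cn2ccnc2c(-c2ccc3ncn(C4CCCCC4)c3c2)n1`, gives 26.8% in a functional assay on SR cells (Homo sapiens) for inhibition, read by sulforhodamine B assay, with a stated time of 48 h, tested at 10 uM; a lower number here means less inhibition, a higher number more inhibition at the concentration tested (going by the name of the read-out).
Compound 2, `COc1ccc(-c2cn3ccnc3c(-c3ccc4ncn(C5CCCCC5)c4c3)n2)cc1`, gives 91.7%.
Compound 3, `Fc1ccc(-c2cn3ccnc3c(-c3ccc4ncn(C5CCCCC5)c4c3)n2)cc1`, gives 20.4%.

Compound 3 sits at the bottom of these three numbers. Its nearest neighbour is compound 1, and the step of a number 6.4 percentage points lower from compound 1 to compound 3 (within the scatter) lies within the scatter, so the two cannot be told apart. Compound 2 stands far above it, as the step of a number 71.3 percentage points lower from compound 2 to compound 3 (beyond the scatter) shows.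

Compound 4, `CC(=O)c1ccc(-c2cn3ccnc3c(-c3ccc4ncn(C5CCCCC5)c4c3)n2)cc1`, is the next one to be measured. It differs from compound 3 in a single place: acetyl in place of fluoro on an aromatic carbon. The aromatic carbon carrying the new group is the same one that carries fluoro in compound 3 and methoxy in compound 2, so two measured steps bear on this change. The step of a number 64.9 percentage points higher from compound 1 to compound 2 (beyond the scatter) shows that a group at this position can lift the number by a large amount, while a number 6.4 percentage points lower from compound 1 to compound 3 (within the scatter) shows that another group there leaves it unchanged. The acetyl group itself has no measured counterpart among these compounds, so the direction of the change is uncertain. The estimate for compound 4 is expected to mean a step of a number 29.6 percentage points higher from compound 3 to compound 4 (beyond the scatter), with a wide margin.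

Compound 4 is estimated at 50%, within a range from 15% to 90%.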

Compound 4, a percentage reported as inhibition, at one concentration (the size of the read-out at that concentration, not a potency): 23.6%
Compound 4: middle estimate off by 26.4 percentage points, on the high side, within the range that was stated.
By their numbers in this assay, from the lowest: compounds 3, 4 and 1 (each within the scatter of the next); then compound 2.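

Acetyl on this aromatic carbon does not carry the number upward in this assay: the step of a number 3.2 percentage points higher from compound 3 to compound 4 (within the scatter) lies within the scatter, and so does the step of a number 3.2 percentage points lower from compound 1 to compound 4 (within the scatter) that replaces bromo with the whole 4-acetylphenyl group. A 4-substituted phenyl group at this place is therefore not enough by itself to lift the number, since compounds 1, 3 and 4 cannot be told apart, and compound 2 is now the only one of the four that stands apart, as the large step of a number 68.1 percentage points lower from compound 2 to compound 4 (beyond the scatter) confirms. The lift thus follows the 4-methoxyphenyl group alone among these compounds, and nothing given here accounts for this difference between methoxy on one side and fluoro and acetyl on the other.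

The compounds shown leave open whether the high number is peculiar to methoxy or would also appear with an ethoxy group, a hydroxy group or an amine on the same carbon. They also leave open how compound 2 would behave across a range of concentrations, as its number comes from a single tested concentration and is not a potency.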